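A few compounds are considered here, and "the series" means these few. Any claim that something is new, unique, unknown or untested is made for them only; others in the source may bear on it.

In an assay on membranes from brain for displacement of a labelled ligand from Neuronal acetylcholine receptor; alpha4/beta2 (Rattus norvegicus) (on this read-out lower numbers stand for stronger inhibition and higher numbers for weaker inhibition), compound 1 `Cc1cncc(OC[C@@H]2CCCN2C)c1` gives 0.48 nM, compound 2 `CCCCCCc1cncc(OC[C@@H]2CCCN2C)c1` gives 0.32 nM, and compound 3 `CN1CCC[C@H]1COc1cncc([N+](=O)[O-])c1` gives 4.65 nM, the highest of the three numbers. The steps of a 9.7-fold higher number from compound 1 to compound 3 (0.99 log units; beyond the scatter) and a 15-fold higher number from compound 2 to compound 3 (1.16 log units; beyond the scatter) both end at compound 3, whereas a 1.5-fold lower number from compound 1 to compound 2 (0.18 log units; within the scatter) stays within the scatter. Compound 4 `COC(=O)c1cncc(OC[C@@H]2CCCN2C)c1` differs from compound 3 by methoxycarbonyl in place of nitro on an aromatic carbon. Going by the values given here, no measured step exchanges nitro for methoxycarbonyl, so the two steps that end at compound 3 bear on it only by showing how far nitro moved the number away from compound 1 and compound 2. Compound 4 is expected to stay near compound 3 in this assay, with an expected step of a 1.3-fold lower number from compound 3 to compound 4 (0.12 log units; within the scatter). The estimate for compound 4 is 3.5 nM, within 0.9 nM to 14 nM.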

Compound 4, inhibition constant: 1.45 nM
Compound 4: the middle estimate sits 2.4-fold (0.38 log units) above what was measured; the range from low to high includes it.
By their numbers in this assay, from the lowest: compounds 2 and 1 (each within the scatter of the next); then compound 4; then compound 3.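

In this assay, the exchange of nitro for methoxycarbonyl on this aromatic carbon, two atoms from the ring nitrogen, gives a 3.2-fold lower number from compound 3 to compound 4 (0.51 log units; beyond the scatter) even though the two groups count the same hydrogen-bond acceptors and donors, so those counts alone do not fix the number at this position. Methoxycarbonyl still falls short of the alkyl groups, with a 3.0-fold higher number from compound 1 to compound 4 (0.48 log units; beyond the scatter) for methyl and a 4.5-fold higher number from compound 2 to compound 4 (0.66 log units; beyond the scatter) for hexyl, and so recovers only part of the ground lost with nitro. On these data alone, whether an amine, a carboxylic acid or an amide here would fall nearer compound 1 or compound 3 stays open. Nothing at hand gives a reason for the gap between nitro and methoxycarbonyl.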